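The source may hold more compounds than are shown below. What is called first, only, known or untested is meant among the compounds shown, and "the series" means these compounds.

Working notes on the series. All numbers here come from an assay on Sf9 cells for inhibition of histone-lysine N-methyltransferase EZH2 (Homo sapiens), read by scintillation counting, with a stated time of 60 min, in the presence of a further agent that is not named here; on this read-out lower numbers stand for stronger inhibition and higher numbers for weaker inhibition. Compound 1 `COc1cccc(C(=O)NCc2c(C)cc(C)[nH]c2=O)c1F` is an open amide whose aromatic ring carries a methoxy group and a fluoro group. In this assay compound 1 returns > 150000 nM, which is a limit of the assay and not a number. Compound 1 thus sits at the limit of > 150000 nM in this assay, at which 1 of the 3 values shown sits. The two other measured compounds close the chain into a ring on a different scaffold: compound 2 `Cc1cc(C)c(CN2CCc3c(Cl)cc(-c4cn[nH]c4)c(Cl)c3C2=O)c(=O)[nH]1` gives 51 nM in this assay, and compound 3 `Cc1cc(C)c(CN2CCc3ccc(OC(C)C)cc3C2=O)c(=O)[nH]1` gives 8100 nM. Against these, compound 1 stands at the weak end of what has been measured, known only as a limit.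

Compound 4 `COc1cccc(C(=O)NCc2c(C)cc(C)[nH]c2=O)c1O` differs from compound 1 in one place: hydroxy in place of fluoro on an aromatic carbon. Within the data shown here, no measured pair in the set makes this same change, so no step can be read off directly. Compound 4 is expected to give 200000 nM, with a range of 50000 nM to 800000 nM. The step is estimated at a step that the limit leaves unreadable from compound 1 to compound 4, which is not expected to rise beyond the scatter in either direction. It is likely that this assay again reports only a limit for compound 4.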

Compound 4, half-maximal inhibitory concentration: 44000 nM
Estimate against measurement, compound 4: 4.5-fold (0.66 log units) above; measured number outside the range, below it.
By their numbers in this assay, from the lowest: compound 2; then compound 3; then compound 4. At a limit, above all of these: compound 1.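

Hydroxy in place of fluoro on an aromatic carbon, ortho to a methoxy group, gives an at least 3.4-fold lower number from compound 1 to compound 4 (0.53 log units; beyond the scatter) in this assay. This position on the open amide therefore responds to the change, and compound 4 gives the open amide a measured number rather than a limit. The true size of the step stays open because compound 1 is known only as a limit: the limit of > 150000 nM in this assay, at which 1 of the 4 values shown sits.

Going by these compounds, the change adds one hydrogen-bond donor and one hydrogen-bond acceptor, but the two compounds alone cannot tell whether either of these accounts for the step, and whether an amine or a carboxylic acid on this same aromatic carbon would move the number in the same direction remains open. Also open is whether hydroxy in place of fluoro would have any comparable effect on the compounds that close the chain into a ring, compound 2 and compound 3, for which no pair with this change is shown.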